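Dimethylphenyl sulfonamides of the imidazolidinone series

The compounds below may be only part of what the source reports. "The series", "measured", "known", "first", "only" and "open" are said of these compounds alone.

Measured so far in a functional assay on MCF7 cells (Homo sapiens) for antiproliferative activity, read by sulforhodamine B assay, with a stated time of 48 h; a higher number here means a weaker inhibitor, a lower number a stronger inhibitor:
compound 1 `COc1ccccc1NS(=O)(=O)c1ccc(N2CCNC2=O)cc1`: 770 nM
compound 2 `Cc1ccc(NS(=O)(=O)c2ccc(N3CCNC3=O)cc2)cc1C`: 230 nM
compound 3 `O=C1NCCN1c1ccc(S(=O)(=O)Nc2ccc(Cl)cc2)cc1`: 170 nM

Compound 3 gives the lowest number of the three, but its gap to compound 2 is within the scatter, so the two cannot be ordered; only compound 1 stands clearly apart, a 4.5-fold lower number from compound 1 to compound 3 (0.66 log units; beyond the scatter) and a 3.3-fold lower number from compound 1 to compound 2 (0.52 log units; beyond the scatter).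

Compound 4 `Cc1ccc(C)c(NS(=O)(=O)c2ccc(N3CCNC3=O)cc2)c1` is next. 2,5-dimethylphenyl in place of 4-chlorophenyl on a sulfonamide nitrogen

For the measured compounds named here, two measured steps bear on it. The step of a 1.4-fold lower number from compound 2 to compound 3 (0.13 log units; within the scatter) shows that exchanging one dimethylphenyl for 4-chlorophenyl moves nothing beyond the scatter, so a dimethylphenyl in this place can sit level with compound 3. Against that, compound 1, the only compound whose group carries a substituent at the 2-position of the phenyl, is the weakest, and a 4.5-fold lower number from compound 1 to compound 3 (0.66 log units; beyond the scatter) is a modest step. The 2,5-dimethylphenyl of compound 4 shares a substituent pattern with neither compound 1 nor compound 2 exactly, so the expectation sits between these two readings: a small rise in the number, probably at the edge of the scatter.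

For compound 4 the expected step is a 2.1-fold higher number from compound 3 to compound 4 (0.31 log units; beyond the scatter); the estimate for compound 4 in this assay is 350 nM, within 150 nM to 900 nM.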

Compound 4, half-maximal inhibitory concentration: 48 nM
Estimate against measurement, compound 4: 7.3-fold (0.86 log units) above; the measured number lies below the stated range.
By their numbers in this assay, from the lowest: compound 4; then compounds 3 and 2 (each within the scatter of the next); then compound 1.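

On the sulfonamide nitrogen, the 2,5-dimethylphenyl of compound 4 separates clearly from both earlier aryl groups that stood level, with a 3.5-fold lower number from compound 3 to compound 4 (0.55 log units; beyond the scatter) and a 4.8-fold lower number from compound 2 to compound 4 (0.68 log units; beyond the scatter); the second step joins two dimethylphenyl groups, so in this assay the arrangement of the two methyl groups matters and not merely their presence. The largest step in the series, a 16-fold lower number from compound 1 to compound 4 (1.21 log units; beyond the scatter), separates 2,5-dimethylphenyl from 2-methoxyphenyl, and this removes any reading that the numeral 2 shared by these two group names goes with a high number. Nothing measured here accounts for these steps.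

The compounds shown leave open whether both methyl groups of the 2,5-dimethylphenyl are needed, a question for the 2-methylphenyl and 3-methylphenyl groups, and whether they can be exchanged, as in 2,5-dichlorophenyl or 2,5-dimethoxyphenyl. Also open, on these data alone, is whether the low number of compound 4 holds once a carboxylic acid or an amine is carried on that phenyl ring, and whether the order of these groups persists on a changed core.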